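Working notes: diethylamino for hydroxy at compound 3

The source may report more compounds than this note shows. Statements on the series, on what has been measured and on what is new or still open speak of the compounds shown alone.

Of the compounds shown here, two have numbers so far. Compound 1 `Cc1cc(C(=O)N2CCCCc3ccccc32)ccc1CNC(=O)NCC(=O)OC(C)C` gives 140 nM in a functional assay on HEK293 cells for agonist activity at Vasopressin V2 receptor (Homo sapiens), read by a luciferase reporter and cAMP accumulation; a lower number here means that less compound is needed, a higher number that more compound is needed for the effect. Within the data shown here, compound 2 `Cc1cc(C(=O)N2CCCCc3ccccc32)ccc1CNC(=O)N1CCC[C@H]1C(=O)O` gives 680 nM in this assay, which is the higher of the two numbers; the only comparison available is a 4.9-fold higher number from compound 1 to compound 2 (0.69 log units; beyond the scatter), a change that swaps the whole urea substituent and so brings in the carboxy group together with the ring.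

Compound 3 `CCN(CC)C(=O)[C@@H]1CCCN1C(=O)NCc1ccc(C(=O)N2CCCCc3ccccc32)cc1C` differs from compound 2 by diethylamino in place of hydroxy on a carbonyl carbon. Among the measured compounds shown here, no measured step isolates this change: the one step in hand, a 4.9-fold higher number from compound 1 to compound 2 (0.69 log units; beyond the scatter), moves from an ester-bearing chain to the carboxy-bearing ring and a substituent at once, so it speaks to the carboxy group only indirectly. With the carboxy group removed in compound 3 and the ring kept, a modest return toward the number of compound 1 is expected rather than a further rise, though a step within the scatter cannot be excluded.

For compound 3 the expected step is a 3.1-fold lower number from compound 2 to compound 3 (0.49 log units; beyond the scatter), giving an estimated 220 nM, with a range from 60 nM to 800 nM.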

Compound 3, half-maximal effective concentration: 350 nM
Compound 3: middle estimate off by 1.6-fold (0.20 log units), on the low side; the range from low to high includes it.
By their numbers in this assay, from the lowest: compound 1; then compounds 3 and 2 (each within the scatter of the next).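

Working notes: at this carbonyl carbon, hydroxy and diethylamino cannot be told apart in this assay, with a 1.9-fold lower number from compound 2 to compound 3 (0.29 log units; within the scatter), so exchanging the carboxy group for diethylcarbamoyl on this ring leaves no change that can be read beyond the scatter. The separation from the open-chain ester remains, with a 2.5-fold higher number from compound 1 to compound 3 (0.40 log units; beyond the scatter), which shows that the gap between the ((isopropoxycarbonyl)methyl)amino substituent and the ring-bearing substituents does not depend on the carboxy group alone. No supporting measurement bears on the reason for either step.

The compounds shown leave open whether the ring or the ester function accounts for the remaining gap, a question that an isopropyl ester on the same ring would separate from the diethylamide and the carboxylic acid. Also open, on these data alone, is how much of the amide can be cut back or varied at this carbonyl carbon, for example with a primary amide, a dimethylamide or a morpholine amide, since a single diethylamide gives no trend with size or with the amide hydrogen.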